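A few compounds are considered here, and "the series" means these few. Any claim that something is new, unique, unknown or untested is made for them only; others in the source may bear on it.

Three compounds of the series carry values in a functional assay on SMMC-7721 cells (Homo sapiens) for cytotoxicity, read by MTT assay, with a stated time of 72 h; a higher number here means a weaker inhibitor, a lower number a stronger inhibitor. Compound 1 `O=C(CSC(=S)N[C@H]1CCOC1=O)Nc1ccc(Br)cc1` gives 28300 nM there. Compound 2 `COc1ccc(NC(=O)CSC(=S)N[C@H]2CCOC2=O)cc1` is reported only as a limit, > 128000 nM. Compound 3 `O=C(CSC(=S)N[C@H]1CCOC1=O)Nc1ccc(F)cc1` is also reported only as a limit, > 128000 nM. Compound 3 thus stands at the limit, weaker than compound 1: the step of an at least 4.5-fold higher number from compound 1 to compound 3 (0.65 log units; beyond the scatter) and the step of an at least 4.5-fold higher number from compound 1 to compound 2 (0.65 log units; beyond the scatter) both run into the limit, while a step that the two limits leave unreadable from compound 2 to compound 3. Compound 4 `CC(=O)c1ccc(NC(=O)CSC(=S)N[C@H]2CCOC2=O)cc1` differs from compound 3 by acetyl in place of fluoro on an aromatic carbon. Going by the values given here, no measured step replaces fluoro with acetyl; the two steps that bear, bromo to fluoro and bromo to methoxy, both reached the limit, so a reading near that limit is expected for compound 4, and an at least 1.4-fold lower number from compound 3 to compound 4 (0.15 log units; that floor lies within the scatter) is expected to remain unreadable against it. The estimate for compound 4 is 90000 nM, ranging from 25000 nM to 300000 nM.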

Compound 4, half-maximal inhibitory concentration: > 128000 nM
Compound 4 gave a limit, no number; the forecaster's own chance of this, stated with the estimate: 55%; middle value at least 1.4-fold (0.15 log units) from the limit.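

In this assay, with an at least 4.5-fold higher number from compound 1 to compound 4 (0.65 log units; beyond the scatter) acetyl on the aromatic carbon para to a large group joins methoxy and fluoro short of bromo, so the change with an added hydrogen-bond acceptor recovers no readable activity. Compound 4 is reported only as a limit, and the steps among compound 2, compound 3 and compound 4 cannot be read: the limit of > 128000 nM in this assay, at which 3 of the 4 values shown sit.

Bromo alone gives a number at this position, so whether chloro, iodo or trifluoromethyl would also give one stays open. From the compounds shown here alone, the outcome with an amine or a carboxylic acid there is equally open.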